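From Anilino to (2-Chlorophenyl)amino

A few compounds are considered here, and "the series" means these few. Any claim that something is new, unique, unknown or untested is made for them only; others in the source may bear on it.

In a functional assay on KB cells (Homo sapiens) for inhibition, read by MTT assay, with a stated time of 24 h, tested at 100 ug/mL (a lower number here means less inhibition of growth, a higher number more inhibition of growth at the concentration tested), compound 1 (`CC(=O)SCCC(CCCCC(=O)O)SC(C)=O`) gives 8.03%, compound 2 (`O=C(CCCCC(S)CCS)Nc1ccccc1`) gives 15.8% and compound 3 (`CC(=O)SCCC(CCCCC(=O)Nc1ccccc1)SC(C)=O`) gives 23%. Compound 3 therefore lies beyond the scatter of compound 1 but within the scatter of compound 2. Compound 4 (`CC(=O)SCCC(CCCCC(=O)Nc1ccccc1Cl)SC(C)=O`) departs from compound 3 in one place: chloro in place of hydrogen on an aromatic carbon.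

The closest measured evidence is a number 15 percentage points higher from compound 1 to compound 3 (beyond the scatter), a modest step made by placing anilino in place of hydroxy on a carbonyl carbon. Going by the values given here, that step shows that the anilino end can move the number, but no measured pair carries a chloro on this ring, so it gives no direction for the new change. No step beyond the scatter is therefore expected in this assay. The expected change is a number 2 percentage points higher from compound 3 to compound 4 (within the scatter). For compound 4 the estimated value is 25%, with an expected range from 13% to 38%.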

Compound 4, percent growth inhibition at one concentration: 6.93%
Compound 4: middle estimate off by 18.1 percentage points, on the high side, outside the stated range (below it).
By their numbers in this assay, from the lowest: compounds 4, 1, 2 and 3 (each within the scatter of the next, the first and the last beyond it).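

In this assay, the ring of the anilino end proves sensitive to a single added chlorine on an aromatic carbon, ortho to a large group: the change gives a number 16.1 percentage points lower from compound 3 to compound 4 (beyond the scatter). The rise that anilino had brought over hydroxy on the carbonyl carbon does not carry over to (2-chlorophenyl)amino, which gives a number 1.1 percentage points lower from compound 1 to compound 4 (within the scatter). No measurement is available that bears on why the chloro has this effect.

On these data alone, it remains open whether fluoro, methyl or methoxy on this same aromatic carbon would lower the number as chloro does. As far as these compounds go, it is also open whether chloro would act in the same way on the free thiol form seen in compound 2.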